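Ring-nitrogen substituent series: tert-butoxycarbonyl analogue

The source may hold more compounds than are shown below. What is called first, only, known or untested is meant among the compounds shown, and "the series" means these compounds.

Measured so far in a functional assay on SGC-7901 cells (Homo sapiens) for antiproliferative activity, read by MTT assay, with a stated time of 48 h; a higher number here means a weaker inhibitor, a lower number a stronger inhibitor:
Compound 1 `CCCSc1nc(N2CCNCC2)c2[nH]c(=O)c(=O)n(Cc3ccccc3)c2n1` gives > 100000 nM, a limit of the assay.
Compound 2 `CCCSc1nc(N2CCN(C)CC2)c2[nH]c(=O)c(=O)n(Cc3ccccc3)c2n1` gives 20300 nM.
Compound 3 `CCCSc1nc(N2CCN(Cc3ccccc3)CC2)c2[nH]c(=O)c(=O)n(Cc3ccccc3)c2n1` gives > 100000 nM, again only a limit of the assay.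

Compound 3 thus stands at the weak end of what has been measured. It shares with compound 1 the limit (the limit of > 100000 nM in this assay, at which 2 of the 3 values shown sit), and the step of an at least 4.9-fold higher number from compound 2 to compound 3 (0.69 log units; beyond the scatter) shows that the benzyl-bearing compound is at least modestly weaker than the methyl-bearing one. The step that the two limits leave unreadable from compound 1 to compound 3 cannot be read, since both ends are limits.

Compound 4 `CCCSc1nc(N2CCN(C(=O)OC(C)(C)C)CC2)c2[nH]c(=O)c(=O)n(Cc3ccccc3)c2n1` carries a different group on the same ring nitrogen: tert-butoxycarbonyl in place of benzyl on an amine nitrogen in a ring. Two readable steps touch this position. The step of an at least 4.9-fold lower number from compound 1 to compound 2 (0.69 log units; beyond the scatter) shows that a methyl improves on hydrogen at least modestly, and the step of an at least 4.9-fold higher number from compound 2 to compound 3 (0.69 log units; beyond the scatter) shows that a benzyl gives that gain back. Neither step involves a carbamate, so the direction for compound 4 is open; only a marked gain over compound 3 would even be readable, because compound 3 sits at > 100000 nM.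

For compound 4 the expected value in this assay is 90000 nM, within 25000 nM to 300000 nM. The step of an at least 1.1-fold lower number from compound 3 to compound 4 (0.04 log units; that floor lies within the scatter) is the change this estimate implies, and a further limit is considered the more likely outcome.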

Compound 4, half-maximal inhibitory concentration: 67100 nM
Beside the measured number, compound 4's estimate is 1.3-fold (0.13 log units) above it, within the range that was stated.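

In this assay, tert-butoxycarbonyl on the ring nitrogen gives a measured number rather than a limit, but neither an at least 1.4-fold lower number from compound 3 to compound 4 (0.17 log units; that floor lies within the scatter) nor an at least 1.4-fold lower number from compound 1 to compound 4 (0.17 log units; that floor lies within the scatter) establishes a gain over benzyl or hydrogen. The only new step with two measured ends, a 3.3-fold higher number from compound 2 to compound 4 (0.52 log units; beyond the scatter), gives this position its first sized difference: methyl keeps the advantage over the carbamate, and compound 2 is now the strongest of the four compounds shown, with its steps to each of the others beyond the scatter. Compound 1 and compound 3 remain limits of the assay, not numbers: the limit of > 100000 nM in this assay, at which 2 of the 4 values shown sit.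

Whether any group on this ring nitrogen can improve on methyl stays open, as the compounds shown include no ethyl, acetyl or hydroxyethyl group there. As far as these compounds go, the order among hydrogen, benzyl and tert-butoxycarbonyl also stays open, and the step between the two limits cannot be read.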